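Epimer at the saturated ring carbon: compound 3 to compound 4

The source may hold more compounds than are shown below. What is called first, only, known or untested is meant among the compounds shown, and "the series" means these compounds.

Measured compounds:
compound 1, `C[C@@]1(c2ccc(OC(F)(F)F)cc2)C[C@@](O)(c2ccccn2)CO1`, 1120 nM
compound 2, `C[C@]1(O)C[C@@](c2cc(C(F)(F)F)ccn2)([C@H](O)c2ccccn2)C1`, 730 nM
compound 3, `O[C@H](c1ccccn1)[C@]1(c2ccc(Cl)c(Cl)c2)CCCO1`, 470 nM

In an assay on HEK293 cells for antagonist activity at transient receptor potential cation channel subfamily V member 3 (Homo sapiens), read by FLIPR and calcium flux (a higher number here means a weaker inhibitor, a lower number a stronger inhibitor), compound 1 gives 1120 nM, compound 2 gives 730 nM and compound 3 gives 470 nM. Compound 3 has the lowest number of the three. Its gap to compound 2 lies within the scatter, so nothing separates those two. Its gap to compound 1 lies beyond the scatter, so compound 3 is the stronger inhibitor of that pair.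

Compound 4, `O[C@H](c1ccccn1)[C@@]1(c2ccc(Cl)c(Cl)c2)CCCO1`, is the next compound. How it differs from compound 3: the two compounds have the same atoms and bonds and differ only in configuration as drawn: 1 of 2 stereo elements differ; a stereocentre at a saturated ring carbon is drawn R in compound 3 and S in compound 4. For the measured compounds named here, no pair of measured compounds in this set differs in only one place, so there is no measured step that would show what a change of configuration at a single stereocentre does here. The three measured compounds also differ from each other in several places at once, and their numbers give no guide to the size of such a step.

Going by the values given here, the expectation is a modest weakening, a step of a 2.6-fold higher number from compound 3 to compound 4 (0.41 log units; beyond the scatter), with a wide range in both directions because the single change of configuration has no measured counterpart among compounds 1 to 3. Compound 4 is estimated at 1200 nM in this assay, between 300 nM and 5000 nM.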

Compound 4, antagonist equilibrium constant: 43 nM
The estimate for compound 4 lay 28-fold (1.45 log units) above the measured number; the whole stated range lies above it.
By their numbers in this assay, from the lowest: compound 4; then compounds 3, 2 and 1 (each within the scatter of the next, the first and the last beyond it).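

In this assay, for the compounds shown here, inverting the stereocentre at the saturated ring carbon from R to S gives an 11-fold lower number from compound 3 to compound 4 (1.04 log units; beyond the scatter), the first step in this set that isolates a single place. Compounds 1, 2 and 3 differ from each other in several places at once and could not show that this position responds to configuration at all, let alone by a large margin. With no atom or bond entering or leaving, the step can be assigned to this stereocentre alone, because nothing else separates the pair: the fact that compounds 3 and 4 differ only in the configuration as drawn

As far as these compounds go, the result rests on one pair, so it remains open whether the S configuration at this carbon would give a step of similar size on a core carrying an amine or a carboxylic acid, or with a longer chain on the saturated ring. From the compounds shown here alone, the second stereo element is the same in compound 3 and compound 4, so the effect of inverting it, alone or together with the first, also remains open.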